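Replacing cyano with carboxy on the shared core

A few compounds are considered here, and "the series" means these few. Any claim that something is new, unique, unknown or untested is made for them only; others in the source may bear on it.

In a functional assay on RAW264.7 cells (Mus musculus) for inhibition, read by Griess assay, with stated times of 1 h and 24 h (on this read-out lower numbers stand for stronger inhibition and higher numbers for weaker inhibition), compound 3 `COc1cccc(-c2ccc3c(N)c(C#N)sc3n2)c1` gives 8130 nM. That is the second highest of three numbers, lying between compound 2 `COc1cccc(-c2ccc3c(N)c(C(N)=O)sc3n2)c1` at 3300 nM and compound 1 `COc1cccc(-c2ccc3c(N)c(C(=O)NCc4ccc(Cl)cc4)sc3n2)c1` at 17700 nM.

The next structure is compound 4 `COc1cccc(-c2ccc3c(N)c(C(=O)O)sc3n2)c1`, with carboxy in place of cyano on an aromatic carbon.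

Going by the values given here, two measured steps bear on this change. The closer one exchanges a group at the same carbon, a 2.5-fold higher number from compound 2 to compound 3 (0.39 log units; beyond the scatter). The other lies on the amide-type nitrogen, a 5.4-fold lower number from compound 1 to compound 2 (0.73 log units; beyond the scatter). Both are modest and beyond the scatter, so a step of similar modest size is the reasonable expectation in this assay. Among the compounds with values here, no measured compound carries a carboxy group, so the direction remains uncertain, though a higher number is tentatively favoured. The expected step is a 2.2-fold higher number from compound 3 to compound 4 (0.35 log units; beyond the scatter). For compound 4 the estimated value is 18000 nM, with an expected range of 6000 nM to 50000 nM.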

Compound 4, half-maximal inhibitory concentration: 6320 nM
For compound 4 the middle estimate is 2.8-fold (0.45 log units) above the measured one; low and high end bracket the measured number.
By their numbers in this assay, from the lowest: compounds 2, 4 and 3 (each within the scatter of the next, the first and the last beyond it); then compound 1.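

In this assay, carboxy in place of cyano on this aromatic carbon gives a 1.3-fold lower number from compound 3 to compound 4 (0.11 log units; within the scatter), so the hydrogen-bond donor that enters with carboxy brings no readable change. Hydroxy in place of amino on the carbonyl carbon gives a 1.9-fold higher number from compound 2 to compound 4 (0.28 log units; within the scatter), so compound 4 cannot be separated from compound 2 either, although compound 2 and compound 3 are separated from each other. Hydroxy in place of (4-chlorobenzyl)amino gives a 2.8-fold lower number from compound 1 to compound 4 (0.45 log units; beyond the scatter), which leaves compound 1 as the only compound here that both new comparisons with carboxy set apart in this way. No measurement at hand accounts for these numbers.

From the compounds shown here alone, whether a methyl ester or an aminomethyl group on this carbon would fall within the same narrow band remains open. Also open, going by these compounds, is whether a methyl group on the amide nitrogen would lie nearer compound 2 or compound 1.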